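Notes on the bis-arylidene series: compound 3 to compound 4

This account rests on a few compounds, and the source may have more. Where it says the series, first, only, none or still open, it means among the compounds named here.

For the measured compounds named here, in an assay on isolated protein for inhibition of Alpha glucosidase (Homo sapiens), with stated times of 5 min and 15 min, tested at 50 uM (a lower number here means less inhibition, a higher number more inhibition at the concentration tested (going by the name of the read-out)), compound 3 `O=C1/C(=C/c2ccccc2)CCC/C1=C\c1ccccc1Br` gives 46.8%, the second highest of the three numbers so far. Compound 1 `O=C1/C(=C/c2ccccc2)CCC/C1=C\c1ccc(Br)cc1` gives 29.1% and compound 2 `O=C1/C(=C/c2ccccc2)CCC/C1=C\c1cccc(O)c1` gives 65.1%, so compound 3 sits between them, with both gaps beyond the scatter: a number 17.7 percentage points higher from compound 1 to compound 3 (beyond the scatter) and a number 18.3 percentage points lower from compound 2 to compound 3 (beyond the scatter).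

Compound 4 `O=C1/C(=C/c2ccccc2)CCC/C1=C\c1cccc(F)c1` differs from compound 3 in one place: 3-fluorophenyl in place of 2-bromophenyl on a double-bonded chain carbon bound to a double-bonded ring carbon.

Going by the values given here, no measured step exchanges a bromine for a fluorine, so the bearing of the known steps is indirect. The largest one, a number 36 percentage points higher from compound 1 to compound 2 (beyond the scatter), shows that a group on the third ring position can carry the highest number of the set, but that group was a hydroxyl and not a halogen. The other two, a number 17.7 percentage points higher from compound 1 to compound 3 (beyond the scatter) and a number 18.3 percentage points lower from compound 2 to compound 3 (beyond the scatter), place the 2-bromophenyl compound 3 below compound 2 and above compound 1. With a halogen moved rather than a hydroxyl introduced, the expectation for the step to compound 4 is a small change in this assay, most likely a slight decrease, a number 4.8 percentage points lower from compound 3 to compound 4 (within the scatter), with the range wide enough to include no change beyond the scatter. Compound 4 is therefore estimated at 42%, expected between 22% and 62%.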

Compound 4, a percentage reported as inhibition, at one concentration (the size of the read-out at that concentration, not a potency): 39.8%
Compound 4: middle estimate off by 2.2 percentage points, on the high side; the range from low to high includes it.
By their numbers in this assay, from the lowest: compound 1; then compounds 4 and 3 (each within the scatter of the next); then compound 2.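

For the compounds shown here, compound 4 gives the first comparison that changes both the halogen and its place on the phenyl ring, and in this assay there is a number 7 percentage points lower from compound 3 to compound 4 (within the scatter) with no separation of the 3-fluorophenyl and 2-bromophenyl compounds. Going by these compounds alone, the first direct exchange on an aromatic carbon, fluoro in place of hydroxy, gives a number 25.3 percentage points lower from compound 2 to compound 4 (beyond the scatter) and so shows that the high number of compound 2 does not carry over to every small group on this phenyl ring at the same ring position. The comparison with the 4-bromophenyl compound gives a number 10.7 percentage points higher from compound 1 to compound 4 (beyond the scatter) and leaves compound 1 with the lowest number and compound 2 with the highest, each beyond the scatter of the other three, while compounds 3 and 4 stay together in the middle.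

With halogen and ring position changing together in the step between compounds 3 and 4, the compounds shown cannot separate the two changes, and they leave open whether a 3-bromophenyl, a 3-aminophenyl or a phenyl ring carrying a carboxylic acid would stand nearer compound 2 or compound 4. Nothing shown here gives a reason for any of these differences.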